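Methoxy in Place of Fluoro on the Benzyl Arm

The source may report more compounds than this note shows. Statements on the series, on what has been measured and on what is new or still open speak of the compounds shown alone.

Within the data shown here, compound 2 `Nc1cc(N)c2nc(-c3ccccc3)c(NCc3ccc(F)cc3)nc2c1` is the only compound here with a plain number. In a functional assay on HCT-15 cells (Homo sapiens) for inhibition, read by sulforhodamine B assay, with a stated time of 48 h (on this read-out higher numbers stand for weaker inhibition of growth and lower numbers for stronger inhibition of growth), compound 2 gives 19100 nM. Compound 1 `COc1ccc(CNc2nc3cc(N)cc(N)c3nc2-c2ccccc2)cc1OC` returns only a limit in this assay, < 100000 nM (the limit of < 100000 nM in this assay, at which 1 of the 2 values shown sits). The step that the limit leaves unreadable from compound 1 to compound 2 is unreadable. Compound 3 `COc1ccc(CNc2nc3cc(N)cc(N)c3nc2-c2ccccc2)cc1` differs from compound 2 by methoxy in place of fluoro on an aromatic carbon. Among the measured compounds shown here, no measured step speaks to this change; the expectation is no shift beyond the usual scatter. Compound 3 is estimated at 19000 nM in this assay, between 6000 nM and 60000 nM. The expected step is a 1.0-fold lower number from compound 2 to compound 3 (0.00 log units; within the scatter).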

Compound 3, concentration for total growth inhibition: 34700 nM
Beside the measured number, compound 3's estimate is 1.8-fold (0.26 log units) below it, and the stated range covers the measured number.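

In this assay, among these compounds, the change from fluoro to methoxy, on an aromatic carbon para to a large group, gives a 1.8-fold higher number from compound 2 to compound 3 (0.26 log units; within the scatter) and is the first readable step in this set. At this position, then, the two groups cannot be told apart on this read-out, and compound 2 and compound 3 count as equal. The steps from compound 1 cannot be read: the limit of < 100000 nM in this assay, at which 1 of the 3 values shown sits.

Still open, from the compounds shown here alone, is whether an amine or a carboxylic acid on this carbon, or a longer chain in place of methoxy, would move the number beyond the scatter. One readable pair also says nothing about other places on the shared core.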